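Adding one methoxy to compound 1: what to expect

The compounds below may be only part of what the source reports. "The series", "measured", "known", "first", "only" and "open" are said of these compounds alone.

Going by the values given here, in a physicochemical assay for lipophilicity (on this read-out higher numbers stand for higher lipophilicity and lower numbers for lower lipophilicity), compound 1 `CCC(=O)Oc1c(OC)c(OC)c(OC(=O)CC)c2ccccc12` gives 3.44 and shares the lowest number of the three measured so far with compound 3 `CCC(=O)Oc1c(OC)c(OC)c(OC(=O)CC)c2c(OC)cccc12`, which gives 3.44 as well. Compound 2 `CC(C)(C)C(=O)Oc1c(Oc2ccccc2)c(Oc2ccccc2)c(OC(=O)C(C)(C)C)c2cc(Cl)ccc12` stands far higher at 8.7 but differs from compound 1 in several places, so it says little about one small change.

The open question is compound 4 `CCC(=O)Oc1c(OC)c(OC)c(OC(=O)CC)c2cc(OC)ccc12`, in which a methoxy takes the place of hydrogen on an aromatic carbon methoxy in place of hydrogen on an aromatic carbon of the shared core, meta to a fused ring and para to a fused ring. Among the compounds with values here, only one measured step bears on this: the same exchange on a different aromatic carbon, which showed no change at the digits printed from compound 1 to compound 3 (within the scatter) in this assay when it was measured. A single example cannot show whether the position of the methoxy matters, so the range is kept fairly wide. No step beyond the scatter is expected in either direction, and the estimated step is no change at the digits printed from compound 1 to compound 4 (within the scatter) for this exchange. The estimate for compound 4 is 3.44 with an expected range from 3.1 to 3.8 on this scale.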

Compound 4, partition coefficient: 3.28
The estimate for compound 4 lay 0.16 log units above the measured number; low and high end bracket the measured number.
By their numbers in this assay, from the lowest: compounds 4, 1 and 3 (each within the scatter of the next); then compound 2.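

In this assay methoxy in place of hydrogen on an aromatic carbon, meta to a fused ring and para to a fused ring, gives a number 0.16 log units lower from compound 1 to compound 4 (within the scatter) and so this position of the shared core now has a measured result of its own. Together with no change at the digits printed from compound 1 to compound 3 (within the scatter) for the same exchange on a different aromatic carbon, this makes two positions where the step stays within the scatter, so the earlier example no longer stands alone, though two positions on one core are too few to make a general rule. Nothing shown here offers an explanation for either result.

The compounds shown leave open whether a larger change at this position, such as an amine, a carboxylic acid or a longer chain in place of the hydrogen, would also stay within the scatter. They also leave open how much each of its differences from compound 1 contributes to the far higher number of compound 2, which gives 8.7 in this assay but differs in several places at once.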